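The source may report more compounds than this note shows. Statements on the series, on what has been measured and on what is new or still open speak of the compounds shown alone.

Compound 3 (`O=C1C(Nc2ccc(Br)cc2)=CC(=O)c2c1nc1n2[C@H]2OC[C@@H](O)[C@H]2OC1`) gives 1980 nM in a functional assay on ECa-109 cells for inhibition, with ECa-109 cell line (Homo sapiens) as the target, read by sulforhodamine B assay (a higher number here means a weaker inhibitor, a lower number a stronger inhibitor), and stands level with compound 1 (`O=C1C(Nc2ccccc2F)=CC(=O)c2c1nc1n2[C@H]2OC[C@@H](O)[C@H]2OC1`), which gives 2660 nM there (a 1.3-fold lower number from compound 1 to compound 3 (0.13 log units; within the scatter)). Compound 2 (`O=C1C(NC2CCCC2)=CC(=O)c2c1nc1n2[C@H]2OC[C@@H](O)[C@H]2OC1`) has no number, only a limit of this assay (> 16000 nM). Compound 3 therefore belongs with compound 1 among the two compounds that have a measured number.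

Compound 4 (`O=C1C(N2CCCC2)=CC(=O)c2c1nc1n2[C@H]2OC[C@@H](O)[C@H]2OC1`) is compound 3 with pyrrolidin-1-yl in place of (4-bromophenyl)amino on a double-bonded ring carbon. The aromatic ring thus gives way to a non-aromatic one, and the hydrogen-bond donor is lost.

The closest guide is compound 2, which also carries a non-aromatic ring on the nitrogen. Two measured steps involve it (an at least 6.0-fold higher number from compound 1 to compound 2 (0.77 log units; beyond the scatter); an at least 8.0-fold lower number from compound 2 to compound 3 (0.90 log units; beyond the scatter)), and both put the aromatic compounds on the stronger side. This rests on compound 2 alone, and its steps are bounded by a limit rather than fixed by two numbers. Within the data shown here, no measured step removes the amine hydrogen, so that part of the change has no guide.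

A clear loss of strength is expected, and the estimated size is a 6.1-fold higher number from compound 3 to compound 4 (0.78 log units; beyond the scatter) in this direction. Compound 4 may also turn out to give only a limit rather than a number. The estimated value for compound 4 is 12000 nM (expected range 4000 nM to 40000 nM).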

Compound 4, half-maximal inhibitory concentration: > 16000 nM
Compound 4 ended at the assay's limit; the forecaster's own chance of this, stated with the estimate: 40%; at least 1.3-fold (0.12 log units) between middle value and limit.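

In this assay, compound 4 gives only a limit, not a number, so the size of each step below is a minimum. Putting pyrrolidin-1-yl in place of (4-bromophenyl)amino on this double-bonded ring carbon costs strength, an at least 8.0-fold higher number from compound 3 to compound 4 (0.90 log units; beyond the scatter), and the change from (2-fluorophenyl)amino reads the same way, an at least 6.0-fold higher number from compound 1 to compound 4 (0.77 log units; beyond the scatter), so among the four compounds shown, the two with an aromatic ring on the nitrogen give numbers and the two with a non-aromatic ring do not. The step between compound 2 and compound 4 cannot be read, so the cyclopentylamino and pyrrolidin-1-yl groups cannot be ranked: the limit of > 16000 nM in this assay, at which 2 of the 4 values shown sit.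

Compound 2 keeps the amine hydrogen and compound 4 lacks it, yet both end at the limit, so any separate effect of losing that hydrogen stays hidden. A methyl group on the nitrogen of the (4-bromophenyl)amino group would keep the aromatic ring without that hydrogen, while a benzylamino group would set the aromatic ring one carbon further from the nitrogen, and the compounds shown say nothing about either.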